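Swapping an Aromatic Side Group Back onto the Shared Core

The source may report more compounds than this note shows. Statements on the series, on what has been measured and on what is new or still open speak of the compounds shown alone.

Measured so far:
- compound 1, `N=C(N)c1ccc(Nc2ncnc(Nc3ccc(S(N)(=O)=O)cc3)c2[N+](=O)[O-])cc1`: 28%
- compound 2, `N=C(N)c1ccc(Nc2ncnc(NCC(N)=O)c2[N+](=O)[O-])cc1`: 49%

Two compounds built on one shared core were tested in an assay on isolated protein for inhibition of protein arginine N-methyltransferase 1 (Homo sapiens), read by AlphaLISA, with a stated time of 60 min, tested at 50 uM; on this read-out higher numbers stand for more inhibition at the one concentration tested (going by the name of the read-out) and lower numbers for less inhibition. Compound 1 `N=C(N)c1ccc(Nc2ncnc(Nc3ccc(S(N)(=O)=O)cc3)c2[N+](=O)[O-])cc1` gives 28% in this assay, and compound 2 `N=C(N)c1ccc(Nc2ncnc(NCC(N)=O)c2[N+](=O)[O-])cc1` gives 49%. Among the compounds with values here, compound 2 stands highest of the two numbers, and the single step of a number 21 percentage points higher from compound 1 to compound 2 (beyond the scatter) lies beyond the scatter, so the group on that nitrogen clearly matters on this read-out.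

Compound 3 `N=C(N)c1ccc(Nc2ncnc(Nc3ccc(N)cc3)c2[N+](=O)[O-])cc1` has not yet been measured. Its difference from compound 2 is 4-aminophenyl in place of carbamoylmethyl on a nitrogen on an aromatic ring. What leaves is carbamoylmethyl; what enters is 4-aminophenyl, a six-membered aromatic ring of carbon only. Within the data shown here, only one measured step bears on this change: a number 21 percentage points higher from compound 1 to compound 2 (beyond the scatter), in which a 4-sulfamoylphenyl group on the same nitrogen gave the lower number. Compound 3 again places an aromatic ring on that nitrogen, though carrying a different group than compound 1, so only part of that step is expected to reverse. The step expected is a number 13 percentage points lower from compound 2 to compound 3 (beyond the scatter), downward. Compound 3 is estimated at 36% in this assay, with a range from 15% to 58%.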

Compound 3, a percentage reported as inhibition, at one concentration (the size of the read-out at that concentration, not a potency): 28%
Compound 3: the middle estimate sits 8 percentage points above what was measured, within the range that was stated.
By their numbers in this assay, from the lowest: compounds 1 and 3 (each within the scatter of the next); then compound 2.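

In this assay the new result shows that the earlier step was not tied to the sulfamoyl group alone: a number 21 percentage points lower from compound 2 to compound 3 (beyond the scatter) and this matches in size the opposite move a number 21 percentage points higher from compound 1 to compound 2 (beyond the scatter) even though the group on the aromatic ring is now a different one. The change of amino in place of sulfamoyl on an aromatic carbon gives no change at the digits printed from compound 1 to compound 3 (within the scatter) so among these three compounds the choice between the two groups on the ring makes no visible difference, while the choice between carbamoylmethyl and a substituted phenyl ring on the nitrogen does, and no compound shown goes against this. Nothing in the available data explains why the read-out follows this pattern.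

Both aromatic groups shown carry a nitrogen-containing substituent on the ring, so it remains open whether an unsubstituted phenyl ring or a saturated ring such as cyclohexyl on that nitrogen would give the same lower number. On the non-aromatic side, only carbamoylmethyl is shown, which leaves open how a longer chain ending in the same amide, or a carboxylic acid in place of that amide, would compare.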